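Swapping a triazole for a tetrazole in an aromatase series

The source may report more compounds than this note shows. Statements on the series, on what has been measured and on what is new or still open speak of the compounds shown alone.

Measured so far:
compound 1, `O=[N+]([O-])c1ccc2c(c1)CC(C(c1ccccc1)n1cncn1)O2`, 58.4%
compound 2, `Fc1ccc(C(C2Cc3ccccc3O2)n2cncn2)cc1`, 98.8%
compound 3, `Clc1ccc(C(C2Cc3ccccc3O2)n2cncn2)c(Cl)c1`, 97.7%

Three compounds share a core built from a dihydrobenzofuran ring joined to a carbon that also carries an aromatic ring and a five-membered nitrogen ring. In an assay for inhibition of Aromatase (Homo sapiens), tested at 20 uM (a higher number here means more inhibition at the concentration tested (going by the name of the read-out), a lower number less inhibition), compound 1 gives 58.4%, the lowest of the three numbers. Compound 2 reaches 98.8% and compound 3 reaches 97.7% in this assay, both well beyond the usual scatter above compound 1. No pair among these three differs in a single place, so no measured step shows what any one change does on its own.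

Compound 4, `O=[N+]([O-])c1ccc2c(c1)CC(C(c1ccccc1)n1cnnn1)O2`, is not yet measured. It differs from compound 1 in one way: 1H-tetrazol-1-yl in place of 1H-1,2,4-triazol-1-yl on a saturated chain carbon bound to an aromatic carbon and a saturated ring carbon

Within the data shown here, nothing among the measured compounds involves a change of the five-membered nitrogen ring, so the direction of this step cannot be read from the data. The expectation for the step in this assay is a number 13.4 percentage points lower from compound 1 to compound 4 (beyond the scatter), a moderate fall, with a drop that is no larger than the scatter being quite possible. For compound 4 in this assay the estimate is 45%, in the range 20% to 70%.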

Compound 4, a percentage reported as inhibition, at one concentration (the size of the read-out at that concentration, not a potency): 14.4%
Estimate against measurement, compound 4: 30.6 percentage points above, outside the stated range (below it).
By their numbers in this assay, from the lowest: compound 4; then compound 1; then compounds 3 and 2 (each within the scatter of the next).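

Holding the rest of compound 1 fixed, this is the first measured change in a single place, and it shows that the five-membered nitrogen ring on the saturated chain carbon matters a great deal in this assay: 1H-tetrazol-1-yl in place of 1H-1,2,4-triazol-1-yl gives a number 44 percentage points lower from compound 1 to compound 4 (beyond the scatter). Both groups hold 5 heavy atoms, so that count does not separate them, whereas the entering ring has 4 hetero atoms and 4 hydrogen-bond acceptors against 3 of each in the leaving ring. Nothing measured here shows which of these differences, if any, lies behind the fall.

From the compounds shown here alone, whether the same swap would lower the number as much on the cores of compound 2 and compound 3, which already sit near the top of this read-out, remains open. Also open, going by these compounds, is how another ring at this position, such as 1H-imidazol-1-yl, would compare with the two rings seen so far, and that comparison would show whether the result is specific to the tetrazole.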